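Longer ester chains and cytotoxicity at one concentration

The source may hold more compounds than are shown below. What is called first, only, known or untested is meant among the compounds shown, and "the series" means these compounds.

Measured compounds:
Compound 1, `CCCOC(=O)CCC(=O)N1CCN(CCCOc2cc3c(Nc4ccc(F)c(Cl)c4)ncnc3cc2OC)CC1`, gives 95.1% in a functional assay on A549 cells (Homo sapiens) for cytotoxicity, read by MTT assay, with a stated time of 24 h, tested at 10 uM; on this read-out higher numbers stand for a weaker effect at the one concentration tested and lower numbers for a stronger effect.
Compound 2, `CCCCOC(=O)CCC(=O)N1CCN(CCCOc2cc3c(Nc4ccc(F)c(Cl)c4)ncnc3cc2OC)CC1`, gives 94.4% in this assay.
Compound 3, `CCCCCOC(=O)CCC(=O)N1CCN(CCCOc2cc3c(Nc4ccc(F)c(Cl)c4)ncnc3cc2OC)CC1`, gives 87.1% in this assay.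

Compound 1 holds the highest of the three numbers. Its nearest neighbour is compound 2, with a number 0.7 percentage points lower from compound 1 to compound 2 (within the scatter), and its furthest is compound 3, with a number 8 percentage points lower from compound 1 to compound 3 (within the scatter); both steps stay within the scatter, so the three compounds cannot be ordered against each other on these data.

Compound 4, `CCCCCCCCCCCCCOC(=O)CCC(=O)N1CCN(CCCOc2cc3c(Nc4ccc(F)c(Cl)c4)ncnc3cc2OC)CC1`, differs from compound 1 by decyl in place of hydrogen on a saturated chain carbon, three bonds along the chain from an oxygen next to a carbonyl group.

Among the measured compounds shown here, the steps that bear on this change are the three chain extensions already measured: a number 0.7 percentage points lower from compound 1 to compound 2 (within the scatter), a number 8 percentage points lower from compound 1 to compound 3 (within the scatter) and a number 7.3 percentage points lower from compound 2 to compound 3 (within the scatter). Each adds one or two carbons at the same kind of place and each gives a small downward number within the scatter. The step to compound 4 adds far more carbons than any measured step, so it is estimated that the number moves further down, a number 11.1 percentage points lower from compound 1 to compound 4 (beyond the scatter), though the measured steps give no ground for a large shift. For compound 4 the value in this assay is expected to be 84%, within a range from 62% to 98%.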

Compound 4, a percentage reported as activity, at one concentration (the size of the read-out at that concentration, not a potency): 93.7%
The estimate for compound 4 lay 9.7 percentage points below the measured number; the measured number falls inside the stated range.
By their numbers in this assay, from the lowest: compounds 3, 4, 2 and 1 (each within the scatter of the next).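

Compound 4 carries decyl at the place three bonds along the chain from an oxygen next to a carbonyl group, and in this assay it stays within the scatter of all three shorter esters (a number 1.4 percentage points lower from compound 1 to compound 4 (within the scatter)) (a number 0.7 percentage points lower from compound 2 to compound 4 (within the scatter)) (a number 6.6 percentage points higher from compound 3 to compound 4 (within the scatter)). The earlier compounds shown here showed this only for the small additions of methyl and ethyl, whereas the new result extends it to a chain far longer than either, so on this read-out, at the one concentration tested, length at this place has so far produced no step beyond the scatter and no trend can be read across the four esters. No supporting measurement is available that would account for this result.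

The compounds shown leave open whether a group of another kind at the end of this ester chain, such as an amine or a carboxylic acid, would give a step beyond the scatter, or whether an aromatic ring there would do so. They also leave open whether these four esters would separate from one another at a higher concentration or after a longer exposure.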